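A methyl in place of bromo on the shared core

The source may hold more compounds than are shown below. What is called first, only, known or untested is meant among the compounds shown, and "the series" means these compounds.

Compound 1 `O=C(CCCc1ccccc1)Nc1nc2ccccc2c(=O)s1` carries the shared core without a substituent on its carbocyclic ring. In an assay on membranes from brain for displacement of a labelled ligand from adenosine receptor A1 (Rattus norvegicus), read by scintillation counting, with a stated time of 90 min (a higher number here means a weaker inhibitor, a lower number a stronger inhibitor), compound 1 gives 229 nM. Compound 2 `O=C(CCCc1ccccc1)Nc1nc2ccc(Br)cc2c(=O)s1` carries bromo on that ring. In this assay compound 2 gives > 10000 nM, which is a limit of the assay rather than a number, namely (the limit of > 10000 nM in this assay, at which 1 of the 2 values shown sits). Within the data shown here, compound 2 therefore stands as the only compound of the two without a numerical value, and the step of an at least 43-fold higher number from compound 1 to compound 2 (1.64 log units; beyond the scatter) is known only as a bound.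

Compound 3 `Cc1ccc2nc(NC(=O)CCCc3ccccc3)sc(=O)c2c1` differs from compound 2 by methyl in place of bromo on an aromatic carbon. Among the measured compounds shown here, the only measured step that bears on this place is an at least 43-fold higher number from compound 1 to compound 2 (1.64 log units; beyond the scatter), where bromo at this carbon carried the value past the limit. Whether methyl at the same carbon behaves like bromo or like hydrogen is not shown by the two compounds measured. The writer estimates the step from compound 2 to compound 3 as an at least 3.3-fold lower number from compound 2 to compound 3 (0.52 log units; beyond the scatter), a move back toward a measurable number. Compound 3 is accordingly expected at 3000 nM, with a range from 500 nM to 20000 nM.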

Compound 3, inhibition constant: 98.3 nM
Compound 3: the middle estimate sits 31-fold (1.48 log units) above what was measured; measured number outside the range, below it.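

The position is not closed to every substituent: in this assay, methyl in place of hydrogen on this aromatic carbon gives a 2.3-fold lower number from compound 1 to compound 3 (0.37 log units; beyond the scatter), a modest change that lies beyond the scatter. Bromo and methyl each bring a single heavy atom, with no hydrogen-bond donors or acceptors and no net charge on either side, yet exchanging one for the other gives an at least 100-fold lower number from compound 2 to compound 3 (2.00 log units; beyond the scatter), so the outcome at this carbon depends on which group stands there and not merely on whether a group is present. That step is a bound and not an exact size, since the value of compound 2 is a limit of the assay: the limit of > 10000 nM in this assay, at which 1 of the 3 values shown sits.

Hydrogen, methyl and bromo at one carbon are too few to set a trend, and it remains open whether chloro, methoxy or an amine there would track methyl or bromo. On these data alone, it is also open whether ethyl or a longer chain at this carbon would lower the number further or send it back towards the limit reached by compound 2.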